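Swapping dimethylamino for diethylamino on the sulfonyl sulfur

This account rests on a few compounds, and the source may have more. Where it says the series, first, only, none or still open, it means among the compounds named here.

Measured compounds:
compound 1, `CCC(CC)S(=O)(=O)c1ccc(S(=O)(=O)N2CCC[C@@H](C(=O)N3CCC(F)(F)CC3)C2)cc1`, 0.285 h
compound 2, `CCN(CC)S(=O)(=O)c1ccc(S(=O)(=O)N2CCC[C@@H](C(=O)NC3COC3)C2)cc1`, 0.308 h
compound 3, `CN(C)S(=O)(=O)c1ccc(S(=O)(=O)N2CCC[C@@H](C(=O)N3CCC(F)(F)CC3)C2)cc1`, > 1 h

Three compounds sharing one core have been run in an ADME assay on microsomes from liver (Homo sapiens) for metabolic stability, read by LC-MS, using NADPH, with a stated time of 60 min, tested at 10 uM; on this read-out higher numbers stand for a longer-lived compound and lower numbers for a shorter-lived compound. Compound 1 gives 0.285 h. Compound 2 gives 0.308 h. For compound 3 the result is only a limit, > 1 h, so its true half-life is known only as lying beyond (the limit of > 1 h in this assay, at which 1 of the 3 values shown sits). Among the compounds with values here, the single step among them, an at least 3.5-fold higher number from compound 1 to compound 3 (0.54 log units; beyond the scatter), shows that a smaller group on the sulfonyl sulfur went with a longer-lived compound.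

Compound 4, `CCN(CC)S(=O)(=O)c1ccc(S(=O)(=O)N2CCC[C@@H](C(=O)N3CCC(F)(F)CC3)C2)cc1`, is not yet measured. It differs from compound 3 by diethylamino in place of dimethylamino on a sulfonyl sulfur. Diethylamino is larger than dimethylamino yet smaller than the pentan-3-yl of compound 1, so the step from compound 3 is expected to run downward, smaller than the upward step from compound 1 to compound 3. Compound 2 also carries a diethylsulfamoyl group, though with a different amide, and its half-life is short. Compound 4 is therefore estimated at 0.5 h, between 0.25 h and 1.2 h, an expected change of an at least 2.0-fold lower number from compound 3 to compound 4 (0.30 log units; that floor lies within the scatter).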

Compound 4, half-life: 0.0457 h
The estimate for compound 4 lay 11-fold (1.04 log units) above the measured number; measured number below the stated range.
By their numbers in this assay, from the lowest: compound 4; then compounds 1 and 2 (each within the scatter of the next). At a limit, above all of these: compound 3.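

Diethylamino in place of dimethylamino on the sulfonyl sulfur gives an at least 21-fold lower number from compound 3 to compound 4 (1.34 log units; beyond the scatter), so a small extension of the groups on the nitrogen can change the half-life sharply. Size alone does not order these groups: pentan-3-yl is larger than diethylamino, yet the change to diethylamino gives a 6.2-fold lower number from compound 1 to compound 4 (0.79 log units; beyond the scatter), so compound 1 goes against the earlier reading that smaller means longer-lived. The amide counts too, since 4,4-difluoropiperidin-1-yl in place of (oxetan-3-yl)amino on a carbonyl carbon, with the diethylsulfamoyl group held fixed, gives a 6.7-fold lower number from compound 2 to compound 4 (0.83 log units; beyond the scatter).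

The full size of the drop stays unknown, as compound 3 stands only at a limit: the limit of > 1 h in this assay, at which 1 of the 4 values shown sits.

Still open, from the compounds shown here alone, is whether a cyclic amine such as pyrrolidine or morpholine on the sulfonyl sulfur would behave like dimethylamino or like diethylamino.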